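A few compounds are considered here, and "the series" means these few. Any claim that something is new, unique, unknown or untested is made for them only; others in the source may bear on it.

In a toxicity assay on Vero cells (Chlorocebus sabaeus) for inhibition, read by MTT assay, with a stated time of 48 h (on this read-out lower numbers stand for stronger inhibition and higher numbers for weaker inhibition), compound 1 `O=C(N/N=C/c1c(-c2cc3ccccc3oc2=O)[nH]c2ccccc12)c1ccccc1Cl` gives > 200000 nM, which is a limit of the assay and not a number. Compound 2 `O=C(N/N=C/c1c(-c2cc3ccccc3oc2=O)[nH]c2ccccc12)c1ccccc1F` gives > 200000 nM, likewise a limit. Among the compounds with values here, compound 3 `O=C(N/N=C/c1c(-c2cc3ccc(Br)cc3oc2=O)[nH]c2ccccc12)c1ccccc1Cl` gives 89300 nM, the only number among the three.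

Compound 1 and compound 2 share a core and differ by fluoro in place of chloro on an aromatic carbon. The step between them, a step that the two limits leave unreadable from compound 1 to compound 2, cannot be sized, since both values sit at the limit of > 200000 nM in this assay, at which 2 of the 3 values shown sit. Compound 3 differs from compound 1 by bromo in place of hydrogen on an aromatic carbon, and here the step is readable: an at least 2.2-fold lower number from compound 1 to compound 3 (0.35 log units; beyond the scatter).

Compound 4 `O=C(N/N=C/c1c(-c2cc3ccc(Br)cc3oc2=O)[nH]c2ccccc12)c1ccccc1F` has not yet been measured. It differs from compound 3 by fluoro in place of chloro on an aromatic carbon, the same change that turns compound 1 into compound 2. The cores of compound 3 and compound 4 differ from those of compound 1 and compound 2 by bromo in place of hydrogen on an aromatic carbon.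

For compound 4 the step is expected to be small, a 1.3-fold higher number from compound 3 to compound 4 (0.13 log units; within the scatter). This expectation rests on a step that the two limits leave unreadable from compound 1 to compound 2, which gives no readable size for this change, and on the value of compound 3, 89300 nM, as the starting point. Compound 4 is therefore estimated at 120000 nM, between 50000 nM and 250000 nM.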

Compound 4, half-maximal inhibitory concentration: > 200000 nM
Compound 4: no number, only a limit; the forecaster's own chance of this, stated with the estimate: 35%; middle value at least 1.6-fold (0.22 log units) from the limit.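

In this assay, going by these compounds, fluoro in place of chloro on the bromo-bearing core gives an at least 2.2-fold higher number from compound 3 to compound 4 (0.35 log units; beyond the scatter), so on this one core the swap from 2-chlorophenyl to 2-fluorophenyl leaves a readable trace, even though its full size stays unknown. The same swap on the core without bromo, and the bromo change between compound 2 and compound 4, cannot be read, since each of those pairs has no number on either side: the limit of > 200000 nM in this assay, at which 3 of the 4 values shown sit. This shows that the swap raises the number on the core of compound 3, but it does not show whether the swap acts to the same extent on the core of compound 1, so nothing here proves or disproves that it carries from one core to the other.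

On these data alone, it remains open how an amine or a carboxylic acid in place of the chloro would read on the core of compound 3 in this assay. As far as these compounds go, it is also open whether a chloro or a methoxy group in place of the bromo would give a number at all.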